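Methyl for trifluoromethyl on the aminopyridine member

A few compounds are considered here, and "the series" means these few. Any claim that something is new, unique, unknown or untested is made for them only; others in the source may bear on it.

Measured so far in a functional assay on RD cells (Homo sapiens) for inhibition, read by luminescence and ATP content, with a stated time of 72 h (a higher number here means that more compound is tolerated, a lower number that less compound is tolerated), and all reported as limits:
- compound 1 `Cc1nc(-c2cnc3ccc(-c4ccc(N)cc4)cc3c2)no1` gives > 2500 nM as a limit
- compound 2 `Nc1ccc(-c2ccc3ncc(-c4noc(C(F)(F)F)n4)cc3c2)cn1` gives > 2500 nM as a limit
- compound 3 `Cc1ccc(-c2ccc3ncc(-c4noc(C(F)(F)F)n4)cc3c2)cc1` gives > 22200 nM as a limit

Compound 2 has only a limit, > 2500 nM and no number. The other two readings are also limits (the limit of > 2500 nM in this assay, at which 2 of the 3 values shown sit) (the limit of > 22200 nM in this assay, at which 1 of the 3 values shown sits) so the series has no numerical value yet.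

Compound 4 `Cc1nc(-c2cnc3ccc(-c4ccc(N)nc4)cc3c2)no1` carries methyl in place of trifluoromethyl on an aromatic carbon of the five-membered ring, counted as methyl in place of trifluoromethyl on an aromatic carbon in the comparison with compound 2.

Among the measured compounds shown here, no measured step covers this change. For the measured compounds named here, the one measured step is a step that the two limits leave unreadable from compound 2 to compound 3 and it concerns a different place, so it offers no size to carry over. Compound 1 also carries the methyl and gives > 2500 nM as a limit.

The expected step is a step that the limit leaves unreadable from compound 2 to compound 4 and nothing beyond the scatter is expected in this assay in either direction. Compound 4 is estimated at 4000 nM with an expected range from 2000 nM to 22000 nM. A limit in place of a number is also quite possible for compound 4.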

Compound 4, half-maximal cytotoxic concentration: > 7400 nM
Compound 4 gave a limit, no number (the forecaster's own chance of this, stated with the estimate: 80%); middle value at least 1.8-fold (0.26 log units) from the limit.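

Compound 4, like compound 1 and compound 2, is recorded only as a limit in this assay, so neither change, from compound 2 or from compound 1 to compound 4, gives a readable step. The compounds shown leave open what half-maximal cytotoxic concentration any of them has.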